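The source may hold more compounds than are shown below. What is called first, only, known or untested is meant among the compounds shown, and "the series" means these compounds.

Measured in a functional assay on HCT-116 cells (Homo sapiens) for cytotoxicity, read by MTT assay, with a stated time of 72 h; a lower number here means a stronger inhibitor, a higher number a weaker inhibitor:

Compound 1 `O=S(=O)(c1ccc(F)cc1)c1nc2ccccc2nc1N1CCc2ccccc2C1` gives 16600 nM
Compound 2 `COc1ccc(S(=O)(=O)c2nc3ccccc3nc2N2CCCC(O)C2)cc1` gives 3520 nM

For the measured compounds named here, only two compounds have numbers so far. Compound 2, at 3520 nM, holds the lower one and is therefore the stronger inhibitor of the pair, and the gap to compound 1 lies beyond the usual scatter.

Compound 3 `O=S(=O)(c1ccc(F)cc1)c1nc2ccccc2nc1N1CCCC(O)C1` takes compound 2 and makes a single change: fluoro in place of methoxy on an aromatic carbon. In words, this is fluoro in place of methoxy on an aromatic carbon, turning 4-methoxyphenyl into 4-fluorophenyl. Going by the values given here, no measured pair shows this change on its own, so its size can only be judged indirectly. Among the compounds with values here, the one measured compound with a 4-fluorophenyl, compound 1, gives 16600 nM, and that is a weak hint at most. A small step toward a higher number in this assay is expected, and it may well stay within the scatter. The expected move is a 1.4-fold higher number from compound 2 to compound 3 (0.15 log units; within the scatter). Compound 3 is estimated at about 5000 nM, with an expected range from 2000 nM to 13000 nM.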

Compound 3, half-maximal inhibitory concentration: 5500 nM
The estimate for compound 3 lay 1.1-fold (0.04 log units) below the measured number; low and high end bracket the measured number.
By their numbers in this assay, from the lowest: compounds 2 and 3 (each within the scatter of the next); then compound 1.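

In this assay, exchanging 4-methoxyphenyl for 4-fluorophenyl with the 3-hydroxypiperidin-1-yl group held constant gives a 1.6-fold higher number from compound 2 to compound 3 (0.19 log units; within the scatter), so this assay does not separate methoxy from fluoro on this aromatic carbon. Compound 3 also provides the first comparison of the other substituent with 4-fluorophenyl held constant: 3-hydroxypiperidin-1-yl in place of 1,2,3,4-tetrahydroisoquinolin-2-yl gives a 3.0-fold lower number from compound 1 to compound 3 (0.48 log units; beyond the scatter), so among these compounds it is this exchange, not the one at the 4-position of the phenyl group, that moves the number beyond the scatter. Nothing available bears on why either step has the size it does.

As far as these compounds go, whether the same indifference extends to other groups on that aromatic carbon, such as a nitrile, a trifluoromethyl group or an amine, remains open, as does whether a larger group there would behave like methoxy and fluoro. From the compounds shown here alone, it is also open how much of the modest step depends on the hydroxyl of 3-hydroxypiperidin-1-yl, a question that an unsubstituted piperidine or a morpholine in the same place would address.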